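The source may hold more compounds than are shown below. What is called first, only, known or untested is meant among the compounds shown, and "the series" means these compounds.

Measured so far, in a functional assay on the whole organism with Rattus norvegicus as the target, at a dose of 100 mg/kg; on this read-out higher numbers stand for more inhibition at the one dose given (going by the name of the read-out) and lower numbers for less inhibition:
compound 1 `N#CNC(=N)NCCCCCCn1nc(-c2ccccc2)ccc1=O` gives 20.5%;
compound 2 `CC/N=C(\S)NCCCCn1nc(-c2ccccc2)ccc1=O` gives 67.7%.

For the measured compounds named here, compound 2 stands highest of these two numbers in this assay, and the only measured step separating it from its neighbour lies well beyond the scatter: a number 47.2 percentage points higher from compound 1 to compound 2 (beyond the scatter). That step swaps one whole chain group for another. Compound 3 `CC(C)C/N=C(\S)NCCCCn1nc(-c2ccccc2)ccc1=O` differs from compound 2 in a single place: isopropyl in place of methyl on a saturated chain carbon bound to a double-bonded nitrogen. Going by the values given here, no measured step bears directly on this kind of change; the one step recorded alters a different group entirely, so it offers no guide to how isopropyl in place of methyl will read in this assay. With nothing pointing either way, the step expected here is a number 5.7 percentage points lower from compound 2 to compound 3 (within the scatter), a shift within the scatter. Compound 3 is therefore estimated to give 62% in this assay, with a likely range from 35% to 85%.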

Compound 3, a percentage reported as inhibition, in the whole organism at one dose (the size of the read-out at that dose, not a potency): 35.8%
Compound 3: middle estimate off by 26.2 percentage points, on the high side; the range from low to high includes it.
By their numbers in this assay, from the lowest: compound 1; then compound 3; then compound 2.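

In this assay, this position proves far from indifferent: isopropyl in place of methyl, on a saturated chain carbon bound to a double-bonded nitrogen, gives a number 31.9 percentage points lower from compound 2 to compound 3 (beyond the scatter). The isopropyl compound still keeps part of the gain over the group in compound 1, with a number 15.3 percentage points higher from compound 1 to compound 3 (beyond the scatter), so most but not all of the rise seen in the step of a number 47.2 percentage points higher from compound 1 to compound 2 (beyond the scatter) is lost with this one change. Nothing measured here explains the drop.

For the compounds shown here, only two groups have been compared at this place, so it remains open whether the numbers fall gradually or abruptly as methyl is replaced. A longer straight chain or an amine in place of methyl would help to settle this, and a second dose would show whether the gap between compound 2 and compound 3 holds.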